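Compound 4: swapping the benzyl group on the triazole series

A few compounds are considered here, and "the series" means these few. Any claim that something is new, unique, unknown or untested is made for them only; others in the source may bear on it.

- compound 1 `COc1ccc(/C=C2\CN(C(=S)SCc3cn(Cc4ccccc4F)nn3)C/C(=C\c3ccc(OC)cc3)C2=O)cc1`: 31500 nM
- compound 2 `COc1ccc(/C=C2\CN(Cc3cn(Cc4cccc(Cl)c4)nn3)C/C(=C\c3ccc(OC)cc3)C2=O)cc1`: 32500 nM
- compound 3 `Cc1ccc(/C=C2\CN(Cc3cn(Cc4ccc(F)cc4)nn3)C/C(=C\c3ccc(C)cc3)C2=O)cc1`: 65600 nM

In a functional assay on PC-3 cells (Homo sapiens) for cytotoxicity, read by MTT assay, with a stated time of 24 h (on this read-out higher numbers stand for weaker inhibition and lower numbers for stronger inhibition), compound 3 (65600 nM) stands highest of the three, and its gaps to compound 2 and to compound 1 both lie just beyond the scatter. The next compound to be measured is compound 4 `Cc1ccc(/C=C2\CN(Cc3cn(Cc4cccc(Cl)c4)nn3)C/C(=C\c3ccc(C)cc3)C2=O)cc1`, which differs from compound 3 in one place 3-chlorophenyl in place of 4-fluorophenyl on a saturated chain carbon bound to an aromatic nitrogen with 3-chlorophenyl in place of 4-fluorophenyl on a saturated chain carbon bound to an aromatic nitrogen.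

For the measured compounds named here, no measured pair isolates this change. The nearest guide is compound 2 (32500 nM), which carries the same 3-chlorobenzyl group but differs from compound 4 on the shared core. The estimated 1.5-fold lower number from compound 3 to compound 4 (0.16 log units; within the scatter) in this assay is a small move towards a lower number, expected to stay within the scatter. Compound 4 is expected at 45000 nM with an estimated range from 24000 nM to 85000 nM on this read-out.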

Compound 4, half-maximal inhibitory concentration: 29300 nM
Compound 4: middle estimate off by 1.5-fold (0.19 log units), on the high side; the range from low to high includes it.
By their numbers in this assay, from the lowest: compounds 4, 1 and 2 (each within the scatter of the next); then compound 3.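

In this assay, placing 3-chlorophenyl in place of 4-fluorophenyl on a saturated chain carbon bound to an aromatic nitrogen gives a 2.2-fold lower number from compound 3 to compound 4 (0.35 log units; beyond the scatter). For the compounds shown here, this is the first step that changes one place only, and it shows that this position responds to the choice of aryl group, modestly but beyond the scatter, with the heavy-atom count and the counts of hydrogen-bond donors and acceptors unchanged. No available evidence bears on what lies behind the step.

The step swaps the halogen and its place on the ring together, so 4-chlorophenyl at this position would be needed to separate the two. On these data alone, whether the step carries over to the core of compound 2, or extends to an unsubstituted phenyl or a pyridine ring, stays open.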